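Tertiary sulfonamide on a shared core: compound 3

The source may hold more compounds than are shown below. What is called first, only, known or untested is meant among the compounds shown, and "the series" means these compounds.

Measured so far:
- compound 1 `CNS(=O)(=O)c1ccc2c(c1)C(n1ccccc1=O)=CC(C)(C)O2` gives 17.8 nM in a functional assay with Rattus norvegicus as the target; on this read-out lower numbers stand for an effect already at smaller amounts and higher numbers for an effect only at larger amounts of compound
- compound 2 `COc1ccc(NS(=O)(=O)c2ccc3c(c2)C(n2ccccc2=O)=CC(C)(C)O3)cc1` gives 117 nM in this assay

For the measured compounds named here, only two compounds have been measured, and they share the same core; they differ only in what sits on the sulfonamide nitrogen. Going by the values given here, compound 2 stands at the higher of the two numbers, with compound 1 as its only neighbour, a step of a 6.6-fold higher number from compound 1 to compound 2 (0.82 log units; beyond the scatter) apart.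

Compound 3 `CN(c1ccccc1)S(=O)(=O)c1ccc2c(c1)C(n1ccccc1=O)=CC(C)(C)O2` is the next compound to be measured. Relative to compound 2, the change is methyl(phenyl)amino in place of (4-methoxyphenyl)amino on a sulfonyl sulfur. This means two things at once: the methoxy group on the aryl ring is gone, and the nitrogen now carries a methyl in place of its hydrogen. Neither of these single changes has been measured on its own. Among the compounds with values here, the only step on record, a 6.6-fold higher number from compound 1 to compound 2 (0.82 log units; beyond the scatter), shows that trading a methyl for an aryl group on that nitrogen raised the number; compound 3 keeps an aryl group there, and adds a methyl, so it is expected to stay nearer compound 2 than compound 1. The step from compound 2 to compound 3 is estimated as a 1.3-fold higher number from compound 2 to compound 3 (0.11 log units; within the scatter), that is, no clear change beyond the scatter. For compound 3 the expected value in this assay is 150 nM, within a range of 40 nM to 600 nM.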

Compound 3, half-maximal effective concentration: 1.74 nM
Compound 3: the middle estimate sits 86-fold (1.94 log units) above what was measured; the whole stated range lies above it.
By their numbers in this assay, from the lowest: compound 3; then compound 1; then compound 2.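

In this assay, an aryl group on the sulfonamide nitrogen does not by itself raise the number: a 10-fold lower number from compound 1 to compound 3 (1.01 log units; beyond the scatter) runs opposite to a 6.6-fold higher number from compound 1 to compound 2 (0.82 log units; beyond the scatter) and shows that phenyl in place of hydrogen can be far better than tolerated when the nitrogen also carries a methyl. The change at this position, on a sulfonyl sulfur, also matters far more than the earlier pair suggested, with a 67-fold lower number from compound 2 to compound 3 (1.83 log units; beyond the scatter) when methyl(phenyl)amino replaces (4-methoxyphenyl)amino. Compound 3 now stands lowest of the three, and its steps to both other compounds lie beyond the scatter, so the sulfonamide nitrogen is a sensitive place on the shared core. Nothing measured alongside these compounds accounts for the size of these steps.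

The step from compound 2 to compound 3 removes the methoxy group and adds the methyl on nitrogen together, so the compounds shown cannot say how much of it belongs to either change. Also open, from the compounds shown here alone, is how the read-out would respond to an ethyl group in place of that methyl, or to a pyridine ring in place of the phenyl.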